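A few compounds are considered here, and "the series" means these few. Any claim that something is new, unique, unknown or untested is made for them only; others in the source may bear on it.

Measured compounds:
- compound 1, `COc1cc(C)cc(-c2nn(CC#N)cc2-c2ccnc(-c3ccc(N(C)C)cc3)c2)c1`: > 1000 nM
- compound 2, `COc1cc(C)cc(-c2nn(CC#N)cc2-c2ccc(-c3cccc(C(C)=O)c3)nc2)c1`: 50800 nM

Of the compounds shown here, two have been tested in a functional assay on NCI-H322M cells (Homo sapiens) for inhibition, read by sulforhodamine B assay, with a stated time of 48 h; on this read-out lower numbers stand for stronger inhibition of growth and higher numbers for weaker inhibition of growth. Compound 1 `COc1cc(C)cc(-c2nn(CC#N)cc2-c2ccnc(-c3ccc(N(C)C)cc3)c2)c1` gives > 1000 nM, which is a limit of the assay and not a number, so where compound 1 truly stands is not known. Compound 2 `COc1cc(C)cc(-c2nn(CC#N)cc2-c2ccc(-c3cccc(C(C)=O)c3)nc2)c1` gives 50800 nM in this assay, a weak result. Compounds 1 and 2 differ in several places, so these two values say nothing about any single change. The unmeasured compound 3 `Cc1cc(O)cc(-c2nn(CC#N)cc2-c2ccnc(-c3ccc(N(C)C)cc3)c2)c1` comes from compound 1 by one change: hydrogen in place of methyl on an oxygen on an aromatic ring. Since one of the two results sits at the limit of > 1000 nM in this assay, at which 1 of the 2 values shown sits, a limit is also a real possibility for compound 3. Among the compounds with values here, no measured pair shows the effect of this change, so the step in this assay is expected to stay within the usual scatter, with no clear direction. The expected step is a step that the limit leaves unreadable from compound 1 to compound 3. Compound 3 is estimated at 10000 nM in this assay, with a likely range from 1500 nM to 80000 nM.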

Compound 3, concentration for total growth inhibition: 59800 nM
Compound 3: middle estimate off by 6.0-fold (0.78 log units), on the low side; measured number inside the range.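

No step can be read from compound 1 to compound 3, because the result for compound 1 is a limit of the assay and not a number: the limit of > 1000 nM in this assay, at which 1 of the 3 values shown sits.

The compounds shown leave open whether the change from methoxy to hydroxy strengthens growth inhibition, weakens it or leaves it unchanged.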